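This account rests on a few compounds, and the source may have more. Where it says the series, first, only, none or still open, it means among the compounds named here.

Measured compounds:

Compound 1 `O=C1N(CCCCCCOc2ccc(Br)cc2)CCN1c1ccncc1`. In a functional assay on cells (Homo sapiens) for cytotoxicity (a lower number here means that less compound is tolerated, a higher number that more compound is tolerated), compound 1 gives > 25000 nM, which is a limit of the assay rather than a number.
Compound 2 `O=C1N(CCCCCCOc2ccc(Cl)cc2)CCN1c1ccncc1`. In this assay compound 2 gives > 25000 nM, again a limit.
Compound 3 `O=C1N(CCCCCCCOc2ccc(Cl)cc2)CCN1c1ccncc1`. In this assay compound 3 gives > 25000 nM, also a limit.

Compound 3 therefore stands at the limit of > 25000 nM in this assay, at which 3 of the 3 values shown sit, the same place as every other measured compound, so no value in the set is a true number. The three steps that connect the measured compounds, a step that the two limits leave unreadable from compound 1 to compound 2, a step that the two limits leave unreadable from compound 1 to compound 3 and a step that the two limits leave unreadable from compound 2 to compound 3, cannot be read in size because both ends of each step are limits. They show only that neither the choice of halogen nor the length of the chain brought any of these compounds into the measurable range.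

Compound 4 `O=C1N(CCCCCCOc2cccc(Br)c2)CCN1c1ccncc1` differs from compound 3 by 3-bromophenoxy in place of (4-chlorophenoxy)methyl on a saturated chain carbon, six bonds along the chain from an amide-type nitrogen in a ring. Among the measured compounds shown here, none of the measured steps tells anything readable about this change, so the expectation rests on the fact that all three measured compounds sit at the limit. The expected step in this assay is therefore none beyond the scatter, written as a number no higher from compound 3 to compound 4 (the limit leaves the size open). Compound 4 is estimated at 25000 nM, with a range from 10000 nM to 100000 nM, most likely again reported only as a limit.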

Compound 4, half-maximal cytotoxic concentration: > 25000 nM
Compound 4: no number, only a limit; the forecaster's own chance of this, stated with the estimate: 85%; the middle value sits exactly at the limit.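

In this assay compound 4 gives > 25000 nM, which is again a limit and not a number. Its steps from compound 1, compound 2 and compound 3 therefore cannot be read in size: the limit of > 25000 nM in this assay, at which 4 of the 4 values shown sit. The compounds shown leave open what change, if any, would give a true number in this assay.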